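Chromene chalcones on HCT-116: removing the bromo group

This account rests on a few compounds, and the source may have more. Where it says the series, first, only, none or still open, it means among the compounds named here.

Measured so far:
- compound 1, `COc1cc(OC)c(OC)cc1/C=C/C(=O)c1ccc(OC)c2c1OC(C)(C)C=C2`: > 10000 nM
- compound 2, `COc1ccc(C(=O)/C=C/c2ccc(Br)cc2)c2c1C=CC(C)(C)O2`: > 10000 nM
- compound 3, `COc1ccc(C(=O)/C=C/c2ccc3ccccc3n2)c2c1C=CC(C)(C)O2`: 4530 nM

In a functional assay on HCT-116 cells (Homo sapiens) for antiproliferative activity, read by MTT assay, with a stated time of 24 h (a higher number here means a weaker inhibitor, a lower number a stronger inhibitor), compound 1 gives only a limit, > 10000 nM. Compound 2 likewise gives only a limit in this assay, > 10000 nM. Within the data shown here, compound 3 is the one member that gives a number in this assay, 4530 nM. Compound 2 therefore stands at the limit of > 10000 nM in this assay, at which 2 of the 3 values shown sit, and its position relative to compound 3 can only be read as "no better than" a weak inhibitor. Among the measured compounds shown here, no step between measured compounds differing in one place is available, so no measured step shows how a single change shifts the read-out.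

Compound 4, `COc1ccc(C(=O)/C=C/c2ccccc2)c2c1C=CC(C)(C)O2`, remains to be measured. It differs from compound 2 by hydrogen in place of bromo on an aromatic carbon. For the measured compounds named here, with compound 2 sitting at a limit > 10000 nM and no measured step to lean on, no shift beyond the scatter is expected in either direction; the expected step from compound 2 to compound 4 is a step that the limit leaves unreadable from compound 2 to compound 4. Compound 4 is estimated at 12000 nM, within 3000 nM to 40000 nM, and most likely reported again only as a limit.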

Compound 4, half-maximal inhibitory concentration: > 10000 nM
Compound 4: no number, only a limit (the forecaster's own chance of this, stated with the estimate: 65%); the middle value is on the limit's open side.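

Compound 2 and compound 4 both give only a limit in this assay, so no step between them can be read; both stand at: the limit of > 10000 nM in this assay, at which 3 of the 4 values shown sit.

The compounds shown leave open whether hydrogen in place of bromo on an aromatic carbon shifts antiproliferative activity at all.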